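Compound 3 to compound 4: replacing the methoxycarbonyl group

The source may hold more compounds than are shown below. What is called first, only, known or untested is meant among the compounds shown, and "the series" means these compounds.

Of the compounds shown here, three have been read so far in a functional assay on HCT-116 cells (Homo sapiens) for antiproliferative activity, read by MTT assay, with a stated time of 72 h (a higher number here means a weaker inhibitor, a lower number a stronger inhibitor), for this series. Compound 1 (`C=CC(=O)N1CCC(Cc2ccccc2)CC1`) gives > 30000 nM as a limit of the assay. Among the compounds with values here, compound 2 (`C=CC(=O)Nc1nc(-c2ccc(C(F)(F)F)cc2)cs1`) gives 4000 nM and is the only one with a number. Compound 3 (`C=CC(=O)N(CC(=O)OC)c1nc(-c2ccccc2)cs1`) gives > 30000 nM as a limit and not a number. Compound 3 thus stands without a measurable potency, and the series shows the limit of > 30000 nM in this assay, at which 2 of the 3 values shown sit, as its main feature.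

Within the data shown here, compound 4 (`C=CC(=O)N(Cc1cc(C)no1)c1nc(-c2ccccc2)cs1`) has 3-methyl-1,2-oxazol-5-yl in place of methoxycarbonyl on a saturated chain carbon bound to an amide-type nitrogen as its one change from compound 3. Cut one bond further out, the same difference reads (methoxycarbonyl)methyl to (3-methyl-1,2-oxazol-5-yl)methyl. Among the measured compounds shown here, no measured pair shows the size of such a change, so the expectation is loose. For the measured compounds named here, compound 2 at 4000 nM is the only guide to how strong a number here can be, and the expectation stays near or weaker than that value. The estimated step is an at least 1.6-fold lower number from compound 3 to compound 4 (0.22 log units; that floor lies within the scatter) and is expected to be modest and towards stronger inhibition, with another reading at the limit quite possible. For compound 4 the estimated value is 18000 nM with an expected range from 5000 nM to 30000 nM as the upper end.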

Compound 4, half-maximal inhibitory concentration: > 30000 nM
Compound 4 was reported as a limit (the forecaster's own chance of this, stated with the estimate: 45%); at least 1.6-fold (0.22 log units) between middle value and limit.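

In this assay compound 3 gives > 30000 nM, a limit of the assay and not a number. Compound 4 gives > 30000 nM, also a limit. No step can be read from compound 3 to compound 4. The compounds shown leave open whether 3-methyl-1,2-oxazol-5-yl in place of methoxycarbonyl changes the antiproliferative potency at all.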